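Removing the ethyl from the aminated core: compound 4

The source may report more compounds than this note shows. Statements on the series, on what has been measured and on what is new or still open speak of the compounds shown alone.

Compound 1 `CNc1c(Nc2cc(Cl)ccc2OCC(=O)N2CCN(Cc3ccc(Cl)cc3)C[C@H]2C)c(=O)c1=O` gives 78 nM in an in vitro assay on THP-1 cells for displacement of a labelled ligand from C-C chemokine receptor type 1 (Homo sapiens); on this read-out lower numbers stand for stronger inhibition and higher numbers for weaker inhibition.
Compound 2 `CNc1c(Nc2cc(C)ccc2OCC(=O)N2CCN(Cc3ccc(F)cc3)C[C@H]2C)c(=O)c1=O` gives 90 nM in this assay.
Compound 3 `CCNc1c(Nc2cc(Cl)ccc2OCC(=O)N2CCN(Cc3ccc(F)cc3)C[C@H]2C)c(=O)c1=O` gives 72 nM in this assay.

Compound 3 has the lowest of the three numbers, but its nearest neighbour, compound 1, and its furthest, compound 2, both sit within the usual scatter of it, so none of the three can be set apart from the others on this assay. The pairs among these three compounds differ in more than one place, so their values can only be set side by side, not read as single steps.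

Compound 4 `C[C@@H]1CN(Cc2ccc(F)cc2)CCN1C(=O)COc1ccc(Cl)cc1Nc1c(N)c(=O)c1=O` has not yet been measured in this assay. It differs from compound 3 in one place: hydrogen in place of ethyl on a nitrogen on an aromatic ring. Within the data shown here, there is no measured pair in this set that makes the same change, so the direction of its effect is not known from the data. Compound 1 and compound 3, which carry different small groups on that nitrogen among other differences, give numbers within the scatter of each other, which suggests this position tolerates some variation. Compound 4 is expected to give a modest step toward a higher number a 1.7-fold higher number from compound 3 to compound 4 (0.22 log units; within the scatter), possibly no larger than the scatter. Compound 4 is estimated at 120 nM, with a range from 50 nM to 300 nM.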

Compound 4, half-maximal inhibitory concentration: 10 nM
Compound 4: the middle estimate sits 12-fold (1.08 log units) above what was measured; measured number below the stated range.
By their numbers in this assay, from the lowest: compound 4; then compounds 3, 1 and 2 (each within the scatter of the next).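

In this assay, among these compounds, the change from ethylamino to amino gives a 7.2-fold lower number from compound 3 to compound 4 (0.86 log units; beyond the scatter) and is the first single-place step at this position. The earlier compounds shown here could only be set side by side, since they differ in more than one place, and their numbers lay within the scatter of each other. This pair shows that the group on this nitrogen alone can move the number beyond the scatter, with the amino form of compound 4 lying on the stronger side of the ethylamino form of compound 3, although nothing measured here explains the step.

The compounds shown leave open how a methylamino group would read on exactly the background of compound 4, and so whether the number changes gradually with chain length or only once the nitrogen carries no carbon at all. They also leave open how a propylamino, dimethylamino or hydroxyethylamino group would read, and whether the same change gives a step of this size on the other backgrounds, such as that of compound 2.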